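The source may hold more compounds than are shown below. What is called first, only, known or untested is meant among the compounds shown, and "the series" means these compounds.

In an ADME assay on a cell-free system (plasma, Rattus norvegicus) for protein binding, read by LC-MS, using equilibrium dialysis, with a stated time of 6 h, tested at 1 uM, so far:
- compound 1 `CN1CC[C@@H](N(c2cc(C#CC(C)(C)C)sc2C(=O)O)C(=O)[C@H]2CC[C@H](C)CC2)C1=O` gives 99.8%
- compound 2 `CN1CCCC[C@@H](N(c2cc(C#CC(C)(C)C)sc2C(=O)O)C(=O)[C@H]2CC[C@H](C)CC2)C1=O` gives 99.8%

Compound 2 stands level with compound 1 on these numbers. Within the data shown here, the one measured step shows no change at the digits printed from compound 1 to compound 2 (within the scatter) for 1-methyl-2-oxoazepan-3-yl in place of 1-methyl-2-oxopyrrolidin-3-yl on an amide-type nitrogen. Among the measured compounds shown here, compound 3 `CN1CCCC[C@H](N(c2cc(C#CC(C)(C)C)sc2C(=O)O)C(=O)[C@H]2CC[C@H](C)CC2)C1=O` relates to compound 2 differently, as the two compounds have the same atoms and bonds and differ only in configuration as drawn: 2 of 3 stereo elements differ; a stereocentre at a saturated ring carbon is drawn R in compound 2 and S in compound 3; a stereocentre at a saturated ring carbon is drawn R in compound 2 and S in compound 3 and no measured step covers a change of configuration, so that step offers only loose guidance. In this assay the expected change is a 1.5-fold higher unbound fraction from compound 2 to compound 3 (0.18 log units; within the scatter) and is not expected to go beyond the scatter. Compound 3 is estimated at 99.7% with an expected range from 99.2% to 99.9% before its measurement.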

Compound 3, plasma protein binding: 99.2%
The estimate for compound 3 lay 2.7-fold (0.43 log units) (unbound fraction) below the measured number; low and high end bracket the measured number.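

In this assay the earlier pair showed no response to ring size, but configuration does register, with a 4.0-fold higher unbound fraction from compound 2 to compound 3 (0.60 log units; beyond the scatter) as the result. Against the smaller ring the result is the same, with a 4.0-fold higher unbound fraction from compound 1 to compound 3 (0.60 log units; beyond the scatter) as the step. The shift between the two larger-ring compounds can be put down to configuration alone because nothing else separates them: the fact that compounds 2 and 3 differ only in the configuration as drawn.

From the compounds shown here alone, two stereocentres change together, so which one carries the step stays open. Going by these compounds, whether an amine on the 1-methyl-2-oxoazepan-3-yl group would leave more compound free also stays open.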